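Replacing the 4-hydroxyphenyl group of compound 3

This account rests on a few compounds, and the source may have more. Where it says the series, first, only, none or still open, it means among the compounds named here.

Values in a functional assay on PC-3 cells (Homo sapiens) for cytotoxicity, read by MTT assay, with a stated time of 48 h (a lower number here means a stronger inhibitor, a higher number a weaker inhibitor), are these:

- Compound 1 `COc1ccc(-c2c[nH]c(=O)n2-c2cc(OC)c(OC)c(OC)c2)cc1OC` gives > 50000 nM as a limit
- Compound 2 `COc1ccc(-c2c[nH]c(=O)n2-c2cc(OC)c(OC)c(OC)c2)cc1[N+](=O)[O-]` gives > 50000 nM as a limit
- Compound 3 `COc1cc(NC(=O)n2cc(-c3ccc(O)cc3)n(-c3cc(OC)c(OC)c(OC)c3)c2=O)cc(OC)c1OC` gives 3000 nM as a number

For the measured compounds named here, compound 3 holds the only number in this set at 3000 nM. The other two readings are limits. Compound 4 `COc1ccc(-c2cn(C(=O)Nc3cc(OC)c(OC)c(OC)c3)c(=O)n2-c2cc(OC)c(OC)c(OC)c2)cc1N` has not yet been measured. Its change from compound 3 is 3-amino-4-methoxyphenyl in place of 4-hydroxyphenyl on an aromatic carbon. Going by the values given here, the one measured step (a step that the two limits leave unreadable from compound 1 to compound 2) puts nitro in place of methoxy and sits on the limit of > 50000 nM in this assay, at which 2 of the 3 values shown sit, at both ends, so it offers no size to carry over. Among the compounds with values here, with no sized step to draw on, the value of compound 3 at 3000 nM remains the anchor, and no step beyond the scatter is expected in this assay in either direction. The expected change is a 1.2-fold lower number from compound 3 to compound 4 (0.08 log units; within the scatter) as an estimate. Compound 4 is estimated at 2500 nM with an expected range from 400 nM to 15000 nM as a deliberately wide span.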

Compound 4, half-maximal inhibitory concentration: 10000 nM
For compound 4 the middle estimate is 4.0-fold (0.60 log units) below the measured one; the range from low to high includes it.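

In this assay, the aromatic carbon next to the ring atom that bears a 3,4,5-trimethoxyphenyl group now gives a step of readable size: 3-amino-4-methoxyphenyl in place of 4-hydroxyphenyl produces a 3.3-fold higher number from compound 3 to compound 4 (0.52 log units; beyond the scatter). For the compounds shown here, the earlier step from compound 1 to compound 2 cannot be read, as both of its ends are limits, so this is the first sized effect of any change in the set, and it shows that this exchange of aryl groups costs only modestly and still leaves a measurable number. Nothing shown accounts for the size of this step.

Going by these compounds, the change removes a hydroxyl and adds an amine and a methoxy together, so which of these carries the step stays open. On these data alone, how a phenyl ring with a lone amine or a lone methoxy, or one with a carboxylic acid, would read at this carbon also remains unknown.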